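The source may report more compounds than this note shows. Statements on the series, on what has been measured and on what is new or still open speak of the compounds shown alone.

Measured so far:
compound 1 `Cc1ccc(CNc2ncnc3c2ncn3[C@@H]2O[C@H](CO)[C@@H](O)[C@H]2O)cc1`: > 166000 nM
compound 2 `OC[C@H]1O[C@@H](n2cnc3c(NCc4ccc(Cl)cc4Cl)ncnc32)[C@H](O)[C@@H]1O`: 127000 nM
compound 3 `COc1cc(O)cc(OC)c1CNc1ncnc2c1ncn2[C@@H]1O[C@H](CO)[C@@H](O)[C@H]1O`: > 166000 nM

In a functional assay on MCF cells (Homo sapiens) for antiproliferative activity, with a stated time of 72 h (on this read-out higher numbers stand for weaker inhibition and lower numbers for stronger inhibition), compound 1 gives only a limit, > 166000 nM. This is the limit of > 166000 nM in this assay, at which 2 of the 3 values shown sit. Compound 3 likewise gives only a limit, > 166000 nM. Compound 2 gives 127000 nM. For the measured compounds named here, the sole measured step, an at least 1.3-fold lower number from compound 1 to compound 2 (0.11 log units; that floor lies within the scatter), changes the same place and lies within the scatter. Compound 4 `Cc1cccc(CNc2ncnc3c2ncn3[C@@H]2O[C@H](CO)[C@@H](O)[C@H]2O)c1O` differs from compound 1 by 2-hydroxy-3-methylphenyl in place of 4-methylphenyl on a saturated chain carbon bound to a nitrogen on an aromatic ring. Going by the values given here, since the one step from compound 1 stays within the scatter and compound 1 and compound 3 both sit at a limit, the step of an at least 1.0-fold lower number from compound 1 to compound 4 (0.01 log units; that floor lies within the scatter) is expected to be none beyond the scatter, most likely again ending at a limit. Compound 4 is therefore estimated at 160000 nM, with a range from 80000 nM to 330000 nM.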

Compound 4, half-maximal inhibitory concentration: 6900 nM
Compound 4: the middle estimate sits 23-fold (1.37 log units) above what was measured; the measured number lies below the stated range.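

At this position, on a saturated chain carbon bound to a nitrogen on an aromatic ring, the choice of ring group can matter in this assay: 2-hydroxy-3-methylphenyl gives an at least 24-fold lower number from compound 1 to compound 4 (1.38 log units; beyond the scatter), and it also gives an 18-fold lower number from compound 2 to compound 4 (1.26 log units; beyond the scatter). Compound 3 also carries a ring hydroxy group, yet it gives only a limit, > 166000 nM. The first step is a floor, not an exact size, as compound 1 also gives only a limit: the limit of > 166000 nM in this assay, at which 2 of the 4 values shown sit.

From the compounds shown here alone, it remains open whether the hydroxy group, the methyl group or their combination accounts for the stronger inhibition. Going by these compounds, it is also open whether an amine in place of that hydroxy group would do the same.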